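This account rests on a few compounds, and the source may have more. Where it says the series, first, only, none or still open, it means among the compounds named here.

Measured compounds:
compound 1 `N#CC1=C(N)OC(c2c[nH]c3ccccc23)=C(C#N)C1c1ccccc1F` — "not active" (no number reported)
compound 2 `COc1ccc(C2C(C#N)=C(N)OC(c3c[nH]c4ccccc34)=C2C#N)cc1OC` — 26.1%
compound 3 `COc1ccc(C2C(C#N)=C(N)OC(c3c[nH]c4ccccc34)=C2C#N)cc1` — 26.4%

In a functional assay, tested at 200 ug/mL (on this read-out lower numbers stand for a weaker effect and higher numbers for a stronger effect at the one concentration tested), compound 1 gives "not active" (no number reported), so no single number marks where it stands; compound 2 gives 26.1% and compound 3 gives 26.4%, and the step of a number 0.3 percentage points higher from compound 2 to compound 3 (within the scatter) leaves the two alongside each other. Compound 4 `N#CC1=C(N)OC(c2c[nH]c3ccccc23)=C(C#N)C1c1ccccc1Cl` has not yet been measured. It differs from compound 1 in one place: chloro in place of fluoro on an aromatic carbon. No measured step swaps one halogen for another, so none of the steps shown bears directly on this change, and the only swap recorded, a number 0.3 percentage points higher from compound 2 to compound 3 (within the scatter), concerns a different group. With compound 1 reported without a number, a step size cannot be set. Compound 4 is expected to give about 12%, in a range from 0% to 35%.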

Compound 4, a percentage reported as activity, at one concentration (the size of the read-out at that concentration, not a potency): 14.5%
Compound 4: the middle estimate sits 2.5 percentage points below what was measured; measured number inside the range.
By their numbers in this assay, from the lowest: compound 4; then compounds 2 and 3 (each within the scatter of the next).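

In this assay compound 1, with 2-fluorophenyl, gives "not active" (no number reported) while compound 4, with 2-chlorophenyl, gives a number, so this single halogen swap separates a reported number from none. Replacing the methoxy-bearing phenyl groups with 2-chlorophenyl lowers the read-out, giving a number 11.9 percentage points lower from compound 3 to compound 4 (beyond the scatter) and a number 11.6 percentage points lower from compound 2 to compound 4 (beyond the scatter) alongside each other. Nothing here explains these differences. Still open, as far as these compounds go, is how bromo or methyl would read at this position, and whether chloro elsewhere on the phenyl ring would give a similar number.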